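The source may report more compounds than this note shows. Statements on the series, on what has been measured and on what is new or still open speak of the compounds shown alone.

Measured in a functional assay on HL-60 cells (Homo sapiens) for inhibition, read by MTT assay, with a stated time of 72 h; on this read-out higher numbers stand for weaker inhibition and lower numbers for stronger inhibition:

- Compound 1 `Cc1nc(-c2ccccc2)c(C(=O)N2CCN(c3cccc(Cl)c3Cl)CC2)o1` gives 133 nM
- Compound 2 `Cc1nc(-c2ccccc2)c(C(=O)N2CCN(c3cccc(C(F)(F)F)c3)CC2)o1` gives 153 nM
- Compound 3 `Cc1nc(-c2ccccc2)c(C(=O)N2CCN(c3ccc(C(=O)C(C)C)cc3)CC2)o1` gives "not active" (no number reported)

Compound 3 has no place on the number scale, since no single value was reported for it. Any step starting from compound 3 therefore has no measurable size, only a possible direction.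

The next compound is compound 4 `Cc1nc(-c2ccccc2)c(C(=O)N2CCN(c3ccccc3)CC2)o1`, and the change is hydrogen in place of isopropylcarbonyl on an aromatic carbon. In words, hydrogen takes the place of isopropylcarbonyl on an aromatic carbon, para to a large group.

Within the data shown here, only one measured step is available: a 1.2-fold higher number from compound 1 to compound 2 (0.06 log units; within the scatter). It swaps 2,3-dichlorophenyl for 3-(trifluoromethyl)phenyl and stays within the scatter. It shows that this one swap changed little, but it says nothing directly about removing isopropylcarbonyl.

The better guide is a plain comparison. Neither compound 1 at 133 nM nor compound 2 at 153 nM carries isopropylcarbonyl, and both gave numbers. Three compounds cannot establish a rule, but a measurable value is expected once the group is gone, with some chance that none is reported.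

In this assay the estimate for compound 4 is 350 nM, expected to lie between 90 nM and 2000 nM.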

Compound 4, half-maximal inhibitory concentration: 39.1 nM
Estimate against measurement, compound 4: 9.0-fold (0.95 log units) above; the whole stated range lies above it.
By their numbers in this assay, from the lowest: compound 4; then compounds 1 and 2 (each within the scatter of the next).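

In this assay, taking isopropylcarbonyl off this aromatic carbon, para to a large group, turns the inactive compound 3 into compound 4 at 39.1 nM, although the step from compound 3 has no readable size, since compound 3 has no number. The ring without any substituent also compares well with the two substituted rings: hydrogen in place of trifluoromethyl gives a 3.9-fold lower number from compound 2 to compound 4 (0.59 log units; beyond the scatter), and phenyl in place of 2,3-dichlorophenyl gives a 3.4-fold lower number from compound 1 to compound 4 (0.53 log units; beyond the scatter). Compounds 1 and 2 alone could not show this, as their values lie within the scatter of each other, whereas compound 4 shows that activity in this series needs no substituent on this ring and that the two substituted rings sit beyond the scatter from the unsubstituted one.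

Nothing available explains why these changes have the effects seen. From the compounds shown here alone, it remains open how a smaller group, such as methyl or methoxy, or an amine or a carboxylic acid would behave at the place where isopropylcarbonyl stood in compound 3.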